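The source may hold more compounds than are shown below. What is called first, only, known or untested is meant among the compounds shown, and "the series" means these compounds.

Compound 3 `COc1ccccc1C=C1CCN(c2ccc(C(=O)NS(=O)(=O)c3ccc(N[C@H](CCN(C)C)CSc4ccccc4)c([N+](=O)[O-])c3)cc2)CC1` gives 2 nM in an assay on isolated protein for displacement of a labelled ligand from Apoptosis regulator Bcl-2 (Homo sapiens), read by fluorescence polarization; on this read-out lower numbers stand for stronger inhibition and higher numbers for weaker inhibition; among the three measured compounds it holds the second highest number, close to compound 1 `CN(C)CC[C@H](CSc1ccccc1)Nc1ccc(S(=O)(=O)NC(=O)c2ccc(N3CCC(=Cc4ccc(F)cc4)CC3)cc2)cc1[N+](=O)[O-]` with 3.4 nM and further from compound 2 `CN(C)CC[C@H](CSc1ccccc1)Nc1ccc(S(=O)(=O)NC(=O)c2ccc(N3CCC(=Cc4ccccc4Cl)CC3)cc2)cc1[N+](=O)[O-]` with 0.7 nM. The steps among them are small: a 1.7-fold lower number from compound 1 to compound 3 (0.23 log units; within the scatter), and a 2.9-fold higher number from compound 2 to compound 3 (0.46 log units; beyond the scatter), while a 4.9-fold lower number from compound 1 to compound 2 (0.69 log units; beyond the scatter).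

Compound 4 `CN(C)CC[C@H](CSc1ccccc1)Nc1ccc(S(=O)(=O)NC(=O)c2ccc(N3CCC(=Cc4ccccn4)CC3)cc2)cc1[N+](=O)[O-]` differs from compound 3 by pyridin-2-yl in place of 2-methoxyphenyl on a double-bonded chain carbon bound to a double-bonded ring carbon. Among the measured compounds shown here, no measured step exchanges the carbon-only ring for a ring with a hetero atom, so the closest guides are the aryl exchanges already seen: compound 1 to compound 3 stays within scatter, and the whole aryl series spans a narrow range. The expectation for compound 4 is therefore a step of a 1.8-fold higher number from compound 3 to compound 4 (0.24 log units; within the scatter) in this assay, most likely within or only just beyond the scatter, with a slightly higher number as the more probable direction since compound 3 itself sits near the upper end of the measured set. Compound 4 is estimated at 3.5 nM, with a range of 1.2 nM to 10 nM.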

Compound 4, inhibition constant: 46 nM
Estimate against measurement, compound 4: 13-fold (1.12 log units) below, and the stated range ends below it.
By their numbers in this assay, from the lowest: compound 2; then compounds 3 and 1 (each within the scatter of the next); then compound 4.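

In this assay the ring on the double-bonded chain carbon bound to a double-bonded ring carbon proves not to be freely exchangeable: pyridin-2-yl brings a 23-fold higher number from compound 3 to compound 4 (1.36 log units; beyond the scatter) and a 14-fold higher number from compound 1 to compound 4 (1.13 log units; beyond the scatter) and also a 66-fold higher number from compound 2 to compound 4 (1.82 log units; beyond the scatter) in the same direction. All three steps are large, whereas compound 1, compound 2 and compound 3, which all carry a carbon-only ring, differ only slightly, so their narrow range does not extend to this ring with a hetero atom. Nothing available here bears on the reason for this rise.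

Compound 4 differs from the others both in its ring nitrogen and in having no substituent on the ring, and the compounds shown do not separate these two changes. Unsubstituted phenyl, pyridin-3-yl, pyridin-4-yl or a chloro-substituted pyridine would help to tell them apart.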